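The source may report more compounds than this note shows. Statements on the series, on what has been measured and on what is new or still open speak of the compounds shown alone.

Measured compounds:
Compound 1 `CC#CCn1c(N2CCC[C@@H](N)C2)cc(=O)n(Cc2ccccc2C(=O)O)c1=O` in an ADME assay on Sf9 cells for inhibition of Dipeptidyl peptidase 9 (Homo sapiens), read by fluorescence, with stated times of 60 s and 20 min; a higher number here means a weaker inhibitor, a lower number a stronger inhibitor: compound 1 gives > 100000 nM, which is a limit of the assay and not a number.
Compound 2 `CC#CCn1c(N2CCC[C@@H](N)C2)cc(=O)n(Cc2cccc(F)c2C(=O)O)c1=O`: compound 2 gives > 100000 nM, again a limit.
Compound 3 `CC#CCn1c(N2CCC[C@@H](N)C2)cc(=O)n(Cc2ccc(Cl)cc2C(=O)O)c1=O`: compound 3 gives > 100000 nM, also a limit.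

Compound 3 stands where the other two stand: all three results sit at the limit of > 100000 nM in this assay, at which 3 of the 3 values shown sit, so none of them can be ranked above or below another. For the same reason the steps between them, a step that the two limits leave unreadable from compound 1 to compound 2, a step that the two limits leave unreadable from compound 1 to compound 3 and a step that the two limits leave unreadable from compound 2 to compound 3, have no readable size. Compound 4 `CC#CCn1c(N2CCC[C@@H](N)C2)cc(=O)n(Cc2ccc(Br)cc2C(=O)O)c1=O` differs from compound 3 by bromo in place of chloro on an aromatic carbon. Going by the values given here, since no measured step has a readable size, nothing in these results shows that exchanging one halogen for another moves the reading in this assay. The step from compound 3 to compound 4 is therefore expected to be a step that the limit leaves unreadable from compound 3 to compound 4, that is, no shift that could be read against a limit. Compound 4 is expected to give about 200000 nM in this assay, with a range from 100000 nM to 1000000 nM, and most likely to be reported only as a limit once more.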

Compound 4, half-maximal inhibitory concentration: > 100000 nM
Compound 4: no number, only a limit; the forecaster's own chance of this, stated with the estimate: 90%; the middle value is on the limit's open side.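

No new step can be read, since compound 4 joins compound 1, compound 2 and compound 3 at a limit of the assay in this assay, and a limit is not a number: the limit of > 100000 nM in this assay, at which 4 of the 4 values shown sit.

The compounds shown leave open whether exchanging one halogen for another changes inhibition at all.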